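Replacing the imidazole arm of compound 1 with a chlorofuran

The source may report more compounds than this note shows. Statements on the series, on what has been measured and on what is new or still open speak of the compounds shown alone.

Measured compounds:
- compound 1 `CC(C)c1[nH]cnc1/C=c1\[nH]c(=O)/c(=C/c2cccc(Oc3ccc(F)cc3)c2)[nH]c1=O` gives 8.8 nM in a functional assay on NCI-H460 cells (Homo sapiens) for cytotoxicity, read by MTT assay, with a stated time of 72 h; on this read-out higher numbers stand for weaker inhibition and lower numbers for stronger inhibition
- compound 2 `O=c1[nH]/c(=C\c2cccc(Oc3ccc(F)cc3)c2)c(=O)[nH]/c1=C\c1cccnc1` reaches only the assay limit of > 1000 nM in this assay

Among the measured compounds shown here, compound 1 holds the only actual number in this assay; the other value shown for the series is a limit. For the measured compounds named here, the one comparable step is an at least 110-fold higher number from compound 1 to compound 2 (2.05 log units; beyond the scatter), a large loss that runs into the limit described by the limit of > 1000 nM in this assay, at which 1 of the 2 values shown sits, so its true size is not known, only its lower bound.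

Compound 3 `O=c1[nH]/c(=C\c2ccc(Cl)o2)c(=O)[nH]/c1=C\c1cccc(Oc2ccc(F)cc2)c1` differs from compound 1 by 5-chlorofuran-2-yl in place of 5-isopropyl-1H-imidazol-4-yl on a double-bonded chain carbon bound to an aromatic carbon. This is the same place on the shared core that was changed from compound 1 to compound 2, and again the five-membered aromatic ring with 2 hetero atoms and its 1 hydrogen-bond donor are removed. Going by the values given here, that single step is the only guide. A large weakening is therefore expected, and the step from compound 1 to compound 3 is estimated at a 68-fold higher number from compound 1 to compound 3 (1.83 log units; beyond the scatter). Compound 3 is expected to give about 600 nM, with a range from 100 nM to 3000 nM, and a fair chance that this assay again reports only a limit.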

Compound 3, half-maximal inhibitory concentration: 180 nM
Compound 3: middle estimate off by 3.3-fold (0.52 log units), on the high side; the measured number falls inside the stated range.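

In this assay, the place on a double-bonded chain carbon bound to an aromatic carbon now has a replacement with a real number: a 20-fold higher number from compound 1 to compound 3 (1.31 log units; beyond the scatter) gives the loss on leaving 5-isopropyl-1H-imidazol-4-yl a measured size. With 0 hydrogen-bond donors in the entering group, compound 3 still gives a number short of the assay limit, so a donor in this group is not needed for measurable activity in this series, although compound 1 remains the stronger of this pair. The outcome also depends on which ring replaces the imidazole, as an at least 5.5-fold lower number from compound 2 to compound 3 (0.74 log units; beyond the scatter) favours 5-chlorofuran-2-yl over pyridin-3-yl, and this step is only a lower bound since compound 2 stands at a limit: the limit of > 1000 nM in this assay, at which 1 of the 3 values shown sits.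

The step from compound 1 to compound 3 changes the isopropyl group, the ring hetero atoms, the donor and the chlorine together, so the share of each in the loss remains unresolved. An imidazole arm carrying a methyl or cyclopropyl group in place of isopropyl, or a furan arm carrying bromine in place of chlorine, would begin to separate these contributions.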